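The compounds below may be only part of what the source reports. "The series", "measured", "known", "first", "only" and "open" are said of these compounds alone.

In a functional assay on THP-1 cells (Homo sapiens) for cytotoxicity, read by MTT assay, with a stated time of 72 h (on this read-out lower numbers stand for stronger inhibition and higher numbers for weaker inhibition), compound 1 (`C=C1CC[C@H]2C(C)(C)CCC[C@]2(C)[C@H]1CCC(C)CC(=O)O`) gives 132000 nM. Compound 2 (`Cc1ccc(/C=C2\CC[C@H]3C(C)(C)CCC[C@]3(C)[C@H]2CCC(C)CC(=O)O)cc1`) gives 91000 nM, and compound 3 (`CC(CC[C@H]1/C(=C/c2ccc([N+](=O)[O-])cc2)CC[C@H]2C(C)(C)CCC[C@]12C)CC(=O)O`) gives 68000 nM. Compound 3 thus has the smallest number of the three, but its gaps to both compound 1 and compound 2 lie within the usual scatter, so these data do not separate it from either one.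

Compound 4 (`CC(CC[C@H]1/C(=C/c2ccc(F)cc2)CC[C@H]2C(C)(C)CCC[C@]12C)CC(=O)O`) has not yet been measured. Its difference from compound 3 is fluoro in place of nitro on an aromatic carbon. In words, this is fluoro in place of nitro on an aromatic carbon, the same difference read further out as 4-nitrophenyl to 4-fluorophenyl.

Within the data shown here, only one measured step bears on this change, and it involves the same aromatic carbon: nitro in place of methyl gave a 1.3-fold lower number from compound 2 to compound 3 (0.13 log units; within the scatter), a step within the scatter. Among the measured compounds shown here, no measured compound shows the fluoro group itself, so the expectation rests on that single step. In this assay, a difference beyond the scatter is therefore not expected, and no direction can be favoured. The estimated step is a 1.2-fold higher number from compound 3 to compound 4 (0.07 log units; within the scatter), which is expected to stay within the scatter. For compound 4 the expected value is 80000 nM, with an estimated range from 45000 nM to 140000 nM.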

Compound 4, half-maximal inhibitory concentration: > 200000 nM
Compound 4 gave a limit, no number; the forecaster's own chance of this, stated with the estimate: 5%; middle value at least 2.5-fold (0.39 log units) away from the limit.
By their numbers in this assay, from the lowest: compounds 3, 2 and 1 (each within the scatter of the next). At a limit, above all of these: compound 4.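

In this assay compound 4 reads only as a limit of the assay, not as a number: the limit of > 200000 nM in this assay, at which 1 of the 4 values shown sits. Even so, the limit shows that this aromatic carbon is not indifferent to what it carries: fluoro in place of nitro gives an at least 2.9-fold higher number from compound 3 to compound 4 (0.46 log units; beyond the scatter), and fluoro in place of methyl gives an at least 2.1-fold higher number from compound 2 to compound 4 (0.34 log units; beyond the scatter), whereas the earlier exchange of methyl for nitro, a 1.3-fold lower number from compound 2 to compound 3 (0.13 log units; within the scatter), could not separate the two groups. Fluoro is thus the first group on this carbon to stand apart from both others, and both new steps are lower bounds, so their true size remains unknown.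

The compounds shown leave open whether another halogen such as chloro or bromo, or an amine or a hydroxyl group, on this same carbon would fall with methyl and nitro or with fluoro. They also leave open whether fluoro would behave in the same way on another carbon of the aromatic ring, and whether an ester or an amide in place of the carboxylic acid would change the picture.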